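This account rests on a few compounds, and the source may have more. Where it says the series, first, only, none or still open, it means among the compounds named here.

Working notes on the series. Compound 2 `Cn1nc(-c2cc(C3CC3)on2)c2c(N)ncnc21` gives 182 nM in an assay on isolated protein for inhibition of proto-oncogene tyrosine-protein kinase receptor Ret variant V804M (Homo sapiens), read by radiometric assay and 33P incorporation, in the presence of a further agent that is not named here; on this read-out higher numbers stand for weaker inhibition and lower numbers for stronger inhibition; of the two measured numbers this is the highest, the nearest being compound 1 `Nc1ncnc2c1c(-c1cc(C3CC3)on1)nn2C1CCCCC1`, which in this assay gives 14 nM. Among the compounds with values here, the only measured step, a 13-fold higher number from compound 1 to compound 2 (1.11 log units; beyond the scatter), is methyl in place of cyclohexyl on an aromatic nitrogen. Compound 3 `Nc1ncnc2c1c(-c1cc(C3CC3)on1)nn2C1CCOCC1` is not yet measured; it differs from compound 2 by oxan-4-yl in place of methyl on an aromatic nitrogen. The change runs against the measured step: methyl at the aromatic nitrogen gives way to a six-membered non-aromatic ring, much as cyclohexyl stood in compound 1. The step of a 13-fold higher number from compound 1 to compound 2 (1.11 log units; beyond the scatter) bears directly on this and was large, so a step of comparable size is expected in this assay, towards a lower number. Within the data shown here, the ring oxygen of oxan-4-yl has no precedent among the measured compounds, which widens the range. Compound 3 is therefore expected to reach 25 nM, with a range from 8 nM to 80 nM. This amounts to an expected step of a 7.3-fold lower number from compound 2 to compound 3 (0.86 log units; beyond the scatter).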

Compound 3, half-maximal inhibitory concentration: 41 nM
Compound 3: the middle estimate sits 1.6-fold (0.21 log units) below what was measured; measured number inside the range.
By their numbers in this assay, from the lowest: compound 1; then compound 3; then compound 2.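

In this assay the move from methyl to oxan-4-yl on the aromatic nitrogen gives a 4.4-fold lower number from compound 2 to compound 3 (0.65 log units; beyond the scatter), so a lower number at this position is no longer tied to cyclohexyl alone and also appears with a six-membered non-aromatic ring holding a hetero atom. The two six-membered rings are nevertheless not interchangeable here: the exchange of cyclohexyl for oxan-4-yl gives a 2.9-fold higher number from compound 1 to compound 3 (0.47 log units; beyond the scatter), which places compound 3 between compound 1 and compound 2 and recovers only part of a 13-fold higher number from compound 1 to compound 2 (1.11 log units; beyond the scatter). No supporting measurement is available to account for either step.

With only methyl, cyclohexyl and oxan-4-yl at this position, the compounds shown do not separate the effect of the ring from that of its size, which an open chain such as n-pentyl or a smaller ring such as cyclobutyl would help to resolve. They also leave open whether the higher number of compound 3 relative to compound 1 is specific to the ring oxygen or would also follow from another ring hetero atom, as in piperidin-4-yl with its ring amine.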